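Swapping an Aryl Group for a Benzyl Group on Nitrogen

The source may report more compounds than this note shows. Statements on the series, on what has been measured and on what is new or still open speak of the compounds shown alone.

For the measured compounds named here, in an ADME assay on C8166 cells (Homo sapiens) for cytotoxicity, read by MTT assay (on this read-out higher numbers stand for lower toxicity in this test and lower numbers for higher toxicity in this test), compound 1 (`Cc1ccc(-n2cc(C(=O)O)c(=O)c3c(O)c(Cc4cccc(Cl)c4F)ccc32)cc1C`) gives 316000 nM, the higher of the two numbers measured so far, which makes it the less toxic of the pair. Compound 2 (`O=C(O)c1cn(Cc2ccccc2F)c2ccc(Cc3ccccc3F)c(O)c2c1=O`) also carries a benzyl group on the nitrogen and gives 67100 nM. Compound 3 (`O=C(O)c1cn(Cc2cccc(F)c2)c2ccc(Cc3cccc(Cl)c3F)c(O)c2c1=O`) has 3-fluorobenzyl in place of 3,4-dimethylphenyl on an aromatic nitrogen. The value of compound 2 points to a lower number, so the expected change, beyond the scatter, is a 3.2-fold lower number from compound 1 to compound 3 (0.50 log units; beyond the scatter). For compound 3 the estimate is 100000 nM, with an expected range of 35000 nM to 260000 nM.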

Compound 3, half-maximal cytotoxic concentration: 69000 nM
For compound 3 the middle estimate is 1.4-fold (0.16 log units) above the measured one, and the stated range covers the measured number.
By their numbers in this assay, from the lowest: compounds 2 and 3 (each within the scatter of the next); then compound 1.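

In this assay, for the compounds shown here, putting 3-fluorobenzyl in place of 3,4-dimethylphenyl on the aromatic nitrogen gives a 4.6-fold lower number from compound 1 to compound 3 (0.66 log units; beyond the scatter) and so shows, for the first time here, a change in toxicity tied to this one position. The two groups have the same number of heavy atoms and one six-membered aromatic ring each, so this position responds even when those counts stay the same. No measurement here explains the shift.

Still open, from the compounds shown here alone, is whether the step comes from the fluorine, the loss of the two methyl groups, or the carbon link to the ring. A plain benzyl group or a 3-fluorophenyl group on the same nitrogen would help separate these.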